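The source may report more compounds than this note shows. Statements on the series, on what has been measured and on what is new or still open speak of the compounds shown alone.

Compound 1 `CCCc1nnc(SCC(=O)c2ccc(Cl)cc2)n1N1C(=O)c2ccccc2C1=O` in a functional assay on HepG2 cells (Homo sapiens) for cytotoxicity, read by MTT assay, with a stated time of 48 h (a lower number here means a stronger inhibitor, a higher number a weaker inhibitor), gives > 200000 nM, which is a limit of the assay and not a number.
Compound 2 `CCCc1nnc(SCC(=O)c2ccc(C)cc2)n1N1C(=O)c2ccccc2C1=O` gives > 200000 nM, again a limit rather than a number.
Compound 3 `CCCc1nnc(SCC(=O)c2ccccc2)n1N1C(=O)c2ccccc2C1=O` gives > 200000 nM, also a limit.

Compound 2 therefore stands only at a limit, with no measured number of its own; all three values sit at the limit of > 200000 nM in this assay, at which 3 of the 3 values shown sit. The measured steps are a step that the two limits leave unreadable from compound 1 to compound 2, a step that the two limits leave unreadable from compound 1 to compound 3 and a step that the two limits leave unreadable from compound 2 to compound 3, so none of them has a readable size. Compound 4 `COc1cc(-c2nnc(SCC(=O)c3ccc(C)cc3)n2N2C(=O)c3ccccc3C2=O)cc(OC)c1OC` differs from compound 2 by 3,4,5-trimethoxyphenyl in place of propyl on an aromatic carbon. Among the compounds with values here, no measured step bears on this change, so no direction can be read from the data. Compound 4 is expected at 200000 nM (range 30000 nM to 500000 nM), most likely again only a limit, meaning an expected step of a number no higher from compound 2 to compound 4 (the limit leaves the size open).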

Compound 4, half-maximal inhibitory concentration: 9440 nM
Compound 4: middle estimate off by 21-fold (1.33 log units), on the high side, outside the stated range (below it).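

In this assay, 3,4,5-trimethoxyphenyl in place of propyl gives an at least 21-fold lower number from compound 2 to compound 4 (1.32 log units; beyond the scatter), so a change at this aromatic carbon of the five-membered ring can move the read-out. The swaps on the far aromatic ring could not show this, as their steps cannot be read. Compound 4 is the only compound shown that leaves the limit: the limit of > 200000 nM in this assay, at which 3 of the 4 values shown sit.

Still open, going by these compounds, is whether the new ring itself or its methoxy groups account for the step, which a plain phenyl group here would help separate. Also open, on these data alone, is whether chloro in place of methyl would now give a readable difference.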